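Oxadiazole-linked indoles: cytotoxicity and a methyl replacement

The source may report more compounds than this note shows. Statements on the series, on what has been measured and on what is new or still open speak of the compounds shown alone.

Compound 1 `c1ccc2c(-c3nnc(-c4ccncc4)o3)c[nH]c2c1` gives 10000 nM in a functional assay on LNCaP cells (Homo sapiens) for cytotoxicity, read by MTT assay; on this read-out lower numbers stand for stronger inhibition and higher numbers for weaker inhibition.
Compound 2 `COc1ccc(-c2nnc(-c3c[nH]c4ccccc34)o2)cc1` reaches only a limit of this assay, > 1000000 nM.
Compound 3 `COc1cc(-c2nnc(-c3cn(C)c4ccccc34)o2)ccc1OCc1ccccc1` likewise reaches only a limit, > 1000000 nM.

Within the data shown here, compound 1 holds the only measured number in this assay; the other two entries are limits (the limit of > 1000000 nM in this assay, at which 2 of the 3 values shown sit). Compound 4 `Cc1nnc(-c2c[nH]c3ccccc23)o1` is not yet measured. It differs from compound 1 by methyl in place of pyridin-4-yl on an aromatic carbon. No step between measured compounds is shown, so the size of this change cannot be read from data; the pyridin-4-yl is the only aromatic group on that carbon among the measured compounds. A loss beyond the scatter is expected, and the estimated step from compound 1 to compound 4 is a 6.0-fold higher number from compound 1 to compound 4 (0.78 log units; beyond the scatter). Compound 4 is estimated at 60000 nM, with a range from 10000 nM to 1000000 nM.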

Compound 4, half-maximal inhibitory concentration: > 1000000 nM
Compound 4 ended at the assay's limit; the forecaster's own chance of this, stated with the estimate: 40%; at least 16-fold (1.22 log units) between middle value and limit.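

In this assay, the change on this carbon of the five-membered ring now has a size: methyl in place of pyridin-4-yl gives an at least 100-fold higher number from compound 1 to compound 4 (2.00 log units; beyond the scatter). The value of compound 4 is a limit of the assay, so this step has no upper end. Compound 1 remains the only compound with a measured number: the limit of > 1000000 nM in this assay, at which 3 of the 4 values shown sit.

The compounds shown leave open whether pyridin-3-yl or unsubstituted phenyl on this carbon would give a measurable value. They also leave open what a longer chain such as butyl, or an amine, would give in place of methyl.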